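Notes on the step from compound 2 to compound 3

The source may report more compounds than this note shows. Statements on the series, on what has been measured and on what is new or still open speak of the compounds shown alone.

Compound 1 `N#Cc1ncc2nc1OCC/C=C\COc1ccccc1NC(=O)N2` is the starting point in a functional assay on NCI-H1299 cells (Homo sapiens), read by flow cytometry; a higher number here means that more compound is needed for the effect, a lower number that less compound is needed. Compound 1 gives > 10000 nM, which is a limit and not a number. Compound 2 `N#Cc1ncc2nc1OCC/C=C\COc1ccc(CCOC3CCCCO3)cc1NC(=O)N2` gives > 10000 nM, which is also only a limit. Compound 2 therefore stands at the limit of > 10000 nM in this assay, at which 2 of the 2 values shown sit. Going by the values given here, the one measured step is a step that the two limits leave unreadable from compound 1 to compound 2, so it provides no size to carry forward.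

Compound 3 `N#Cc1ncc2nc1OCC/C=C\COc1ccc(CCCO)cc1NC(=O)N2` differs from compound 2 as follows: hydroxymethyl in place of (oxan-2-yl)oxy on a saturated chain carbon, two bonds along the chain from an aromatic carbon. Hydroxymethyl replaces (oxan-2-yl)oxy on a saturated chain carbon, two bonds along the chain from an aromatic carbon, giving 3-hydroxypropyl. No measured step sizes this change, so a reading at the same limit in this assay remains quite likely. The expected step, only weakly founded, is an at least 1.6-fold lower number from compound 2 to compound 3 (0.22 log units; that floor lies within the scatter). For compound 3 the estimated value is 6000 nM, with an expected range of 1000 nM to 20000 nM.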

Compound 3, half-maximal effective concentration: > 10000 nM
Compound 3: no number, only a limit; the forecaster's own chance of this, stated with the estimate: 55%; middle value at least 1.6-fold (0.22 log units) away from the limit.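

In this assay compound 3 gives > 10000 nM, which is a limit and not a number. No step among compound 1, compound 2 and compound 3 can be read: the limit of > 10000 nM in this assay, at which 3 of the 3 values shown sit.

The compounds shown leave open whether any change to the core of compound 1 gives a measurable value in this assay.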